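Urea to benzamide on the pyrazole-linked aniline

This account rests on a few compounds, and the source may have more. Where it says the series, first, only, none or still open, it means among the compounds named here.

Measured compounds:
compound 1 `COc1cc(-c2nn(-c3cccc(NC(=O)Nc4ccc(Cl)c(Cl)c4)c3)cc2-c2ccncc2)ccc1Cl` — 698 nM
compound 2 `O=C(Nc1cccc(-n2cc(-c3ccncc3)c(-c3ccc(Cl)c(O)c3)n2)c1)Nc1ccc(Cl)c(Cl)c1` — 1180 nM
compound 3 `O=C(Nc1cccc(-n2cc(-c3ccncc3)c(-c3ccc(Cl)c(O)c3)n2)c1)Nc1cc(C(F)(F)F)cc(C(F)(F)F)c1` — 739 nM

In a functional assay on MDA-MB-231 cells (Homo sapiens) for inhibition, read by sulforhodamine B assay, with a stated time of 48 h (a lower number here means a stronger inhibitor of growth, a higher number a weaker inhibitor of growth), compound 1 gives the lowest of the three numbers, but its neighbours sit close: compound 3 is within the scatter of it, and the step of a 1.7-fold higher number from compound 1 to compound 2 (0.23 log units; within the scatter) is likewise within the scatter, so no ordering among the three is claimed.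

Compound 4 `COc1cc(-c2nn(-c3cccc(NC(=O)c4ccccc4)c3)cc2-c2ccncc2)ccc1Cl` is not yet measured. It differs from compound 1 in one place: phenyl in place of (3,4-dichlorophenyl)amino on a carbonyl carbon. Going by the values given here, no measured step touches this part of the molecule. Among the compounds with values here, the one step on record, a 1.7-fold higher number from compound 1 to compound 2 (0.23 log units; within the scatter), concerns a methyl on an oxygen at the other end of the core and is within the scatter, so it says nothing about the urea terminus. Compounds 2 and 3 differ only in the aryl carried by the urea, and their two values lie within the scatter of each other; this hints that the distal aryl itself is not decisive, but neither pair removes the urea nitrogen as the present change does. The expectation for compound 4 is therefore a weaker growth inhibitor than compound 1, with wide uncertainty: the estimated step is a 2.9-fold higher number from compound 1 to compound 4 (0.46 log units; beyond the scatter). Compound 4 is estimated at 2000 nM, expected to fall between 700 nM and 6000 nM.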

Compound 4, concentration for 50% growth inhibition: 1170 nM
Estimate against measurement, compound 4: 1.7-fold (0.23 log units) above; measured number inside the range.
By their numbers in this assay, from the lowest: compounds 1, 3, 4 and 2 (each within the scatter of the next).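

In this assay, going by these compounds alone, the urea terminus is now changed for the first time on the core of compound 1, and the step of a 1.7-fold higher number from compound 1 to compound 4 (0.22 log units; within the scatter) shows that the urea can give way to a benzamide without a difference that can be read. This change removes the urea nitrogen, with its hydrogen-bond donor, and both chlorine atoms in a single move, so neither the (3,4-dichlorophenyl)amino group as a whole nor the urea linkage is required for growth inhibition at the level of compound 1 in this cell line, although the separate contribution of the nitrogen and of the chlorines cannot be read from this one pair. Nothing on hand explains why the number holds across this change.

On these data alone, a benzamide carrying 3,4-dichlorophenyl on the carbonyl carbon would separate the loss of the urea nitrogen from the loss of the chlorines, and that comparison remains open. Also open, as far as these compounds go, is whether an amine or a carboxylic acid on the phenyl of compound 4, or a longer chain in its place, would give a step beyond the scatter.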